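Bromo for trifluoromethyl on a phenylethyl urea

A few compounds are considered here, and "the series" means these few. Any claim that something is new, unique, unknown or untested is made for them only; others in the source may bear on it.

Compound 1 `C[C@@H](NC(=O)Nc1cccc(C(F)(F)F)c1)c1ccccc1`: 70%
Compound 2 `C[C@H](NC(=O)Nc1cccc(C(F)(F)F)c1)c1ccccc1`: 92%
Compound 3 `COc1ccccc1NC(=O)N[C@@H](C)c1ccccc1`: 95%

In an ADME assay on the whole organism with Oryza sativa as the target, tested at 10 uM (a lower number here means a stronger effect, a higher number a weaker effect of the compound at the concentration tested), compound 2 gives the second highest of the three numbers. Compound 3 lies within the scatter of it, while compound 1 lies well below it. For the measured compounds named here, the only measured step, a number 22 percentage points higher from compound 1 to compound 2 (beyond the scatter), comes from a change of configuration alone, as the fact that compounds 1 and 2 differ only in the configuration as drawn shows; it says nothing about swapping a group on the aromatic ring.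

Compound 4 `C[C@H](NC(=O)Nc1cccc(Br)c1)c1ccccc1` differs from compound 2 by bromo in place of trifluoromethyl on an aromatic carbon, so bromo in place of trifluoromethyl on an aromatic carbon, meta to a large group. Going by the values given here, no measured pair of compounds shows such a swap, so no step bears directly on it. With nothing pointing either way, the expected step is small: the estimate is a number 4 percentage points lower from compound 2 to compound 4 (within the scatter), no move beyond the scatter. Compound 4 is therefore expected to give 88%, in a range from 70% to 100%.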

Compound 4, a percentage reported as activity, at one concentration (the size of the read-out at that concentration, not a potency): 99%
Compound 4: the middle estimate sits 11 percentage points below what was measured; the measured number falls inside the stated range.
By their numbers in this assay, from the lowest: compound 1; then compounds 2, 3 and 4 (each within the scatter of the next).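

In this assay, putting bromo in place of trifluoromethyl on the aromatic carbon gives a number 7 percentage points higher from compound 2 to compound 4 (within the scatter), so this swap does not shift the read-out by more than repeat measurements usually do. For the compounds shown here, this is the first direct look at a change on the aromatic ring rather than in configuration, and with the configuration of compound 2, a single bromine atom can take the place of the four heavy atoms of trifluoromethyl without a change that can be told from the scatter. Nothing at hand explains why the read-out responds so little to this swap.

As far as these compounds go, it remains open whether the same swap would read alike on the configuration drawn in compound 1, which gives the lower number of that pair. Also open, from the compounds shown here alone, is what an amine, a nitrile or a carboxylic acid on that aromatic carbon would give.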